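Carbonyl-carbon group change from compound 3 to compound 4

The compounds below may be only part of what the source reports. "The series", "measured", "known", "first", "only" and "open" are said of these compounds alone.

The series comprises compound 1 (`CC[C@@H]1CC[C@@H](C(=O)N2CCN(C(C)=O)CC2)N1C(=O)C1=C(C(C)C)N2C(=N[C@@](C)(c3ccc(Cl)cc3)[C@H]2c2ccc(Cl)cc2)S1`), compound 2 (`CC[C@@H]1CC[C@@H](C(=O)N2CCOCC2)N1C(=O)C1=C(C(C)C)N2C(=N[C@@](C)(c3ccc(Cl)cc3)[C@H]2c2ccc(Cl)cc2)S1`), compound 3 (`CC[C@@H]1CC[C@@H](C(=O)N2CCN(C)[C@@H](C)C2)N1C(=O)C1=C(C(C)C)N2C(=N[C@@](C)(c3ccc(Cl)cc3)[C@H]2c2ccc(Cl)cc2)S1`) and the unmeasured compound 4 (`CC[C@@H]1CC[C@@H](C(=O)N2CCN(C(C)=O)[C@H](C)C2)N1C(=O)C1=C(C(C)C)N2C(=N[C@@](C)(c3ccc(Cl)cc3)[C@H]2c2ccc(Cl)cc2)S1`), which share a core and differ in the group on a carbonyl carbon. In a functional assay on DLD-1 cells (Homo sapiens) for inhibition, read by luminescence, with a stated time of 3 days (a lower number here means a stronger inhibitor of growth, a higher number a weaker inhibitor of growth), compound 1 gives 9300 nM, compound 2 gives 4200 nM and compound 3 gives 3900 nM. Compound 3 is level with compound 2, as a 1.1-fold lower number from compound 2 to compound 3 (0.03 log units; within the scatter) stays within the scatter. Both stand modestly lower than compound 1, with a 2.2-fold lower number from compound 1 to compound 2 (0.35 log units; beyond the scatter) and a 2.4-fold lower number from compound 1 to compound 3 (0.38 log units; beyond the scatter).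

Compound 4 loses the 3,4-dimethylpiperazin-1-yl of compound 3, on a carbonyl carbon: a group of 10 heavy atoms (7 carbon, 2 nitrogen, 1 oxygen; one six-membered non-aromatic ring with 2 hetero atoms) in place of a group of 8 heavy atoms (6 carbon, 2 nitrogen; one six-membered non-aromatic ring with 2 hetero atoms), on a carbonyl carbon. The entering group carries the acetyl found in the 4-acetylpiperazin-1-yl of compound 1, so the most relevant measurement is a 2.4-fold lower number from compound 1 to compound 3 (0.38 log units; beyond the scatter), read in reverse. Among the compounds with values here, no measured pair isolates the remaining structural difference, so the size stays uncertain. The expected change is a modest rise in the number in this assay, meaning weaker growth inhibition: a 2.1-fold higher number from compound 3 to compound 4 (0.31 log units; beyond the scatter). For compound 4 the estimated value is 8000 nM, with an expected range of 4500 nM to 14000 nM.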

Compound 4, concentration for 50% growth inhibition: 10000 nM
For compound 4 the middle estimate is 1.3-fold (0.10 log units) below the measured one; the measured number falls inside the stated range.
By their numbers in this assay, from the lowest: compounds 3 and 2 (each within the scatter of the next); then compounds 1 and 4 (each within the scatter of the next).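

In this assay, a 1.1-fold higher number from compound 1 to compound 4 (0.03 log units; within the scatter) shows that methyl in place of hydrogen on a saturated ring carbon of the acetyl-bearing piperazine leaves the number level, so this ring methyl gives no readable gain or loss in that setting. The acetyl-bearing group also separates compound 4 from the other two groups, with a 2.6-fold higher number from compound 3 to compound 4 (0.41 log units; beyond the scatter) and a 2.4-fold higher number from compound 2 to compound 4 (0.38 log units; beyond the scatter) both modest and beyond the scatter, and compound 1 falls on the same side as compound 4 in its steps to compounds 2 and 3. No supporting data bear on why these groups differ in this way. Still open, going by these compounds, is how a free piperazin-1-yl amine or a longer acyl chain such as propanoyl would compare with the acetyl. A plain 4-methylpiperazin-1-yl would also show whether the ring methyl of compound 3 has any effect in the absence of acetyl.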